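Swapping Fluorines for Methyls on the Urea Anilide

This account rests on a few compounds, and the source may have more. Where it says the series, first, only, none or still open, it means among the compounds named here.

Compound 3 `O=C(Nc1c(F)cc(F)cc1F)N(Cc1ccc(-c2ccccn2)cc1)C1CCCCCC1` is known in a functional assay on a cell-free system (plasma) with sterol O-acyltransferase, Soat (Rattus norvegicus) as the target (a lower number here means that less compound is needed, a higher number that more compound is needed for the effect), only as a limit and not a number, where compound 3 gives > 1 mg/kg. That is one of the limits seen here, (the limit of > 1 mg/kg in this assay, at which 1 of the 3 values shown sits). Compound 4 `Cc1cc(C)c(NC(=O)N(Cc2ccc(-c3ccccn3)cc2)C2CCCCCC2)c(C)c1` differs from compound 3 in one place: 2,4,6-trimethylphenyl in place of 2,4,6-trifluorophenyl on an amide-type nitrogen. Among the measured compounds shown here, none of the measured steps follows this same change. For the measured compounds named here, the one measured step, an at least 1.1-fold lower number from compound 1 to compound 2 (0.05 log units; that floor lies within the scatter), concerns a different position, the group on the aromatic carbon, and stays within the scatter. What the compounds carrying the entering 2,4,6-trimethylphenyl show is this: compound 2 `Cc1cc(C)c(NC(=O)N(Cc2ccc(-c3cccs3)cc2)C2CCCCCC2)c(C)c1` gives 0.28 mg/kg in this assay. Compound 1 `Cc1cc(C)c(NC(=O)N(Cc2ccc(-c3nnc(C)o3)cc2)C2CCCCCC2)c(C)c1` gives > 0.32 mg/kg in this assay, which is a limit and not a number, (the limit of > 0.32 mg/kg in this assay, at which 1 of the 3 values shown sits). So compounds with the entering group reach a measurable dose in one case and stop at a limit in the other. For compound 4 the step of an at least 2.0-fold lower number from compound 3 to compound 4 (0.30 log units; that floor lies within the scatter) is expected to bring the dose into the measurable range, though the measurement may again end at a limit. Compound 4 is therefore estimated at 0.5 mg/kg, with a range from 0.15 mg/kg to 2 mg/kg.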

Compound 4, dose for half-maximal effect: > 1 mg/kg
Compound 4 gave a limit, no number; the forecaster's own chance of this, stated with the estimate: 40%; at least 2.0-fold (0.30 log units) between middle value and limit.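

Pyridin-2-yl in place of thiophen-2-yl gives an at least 3.5-fold higher number from compound 2 to compound 4 (0.55 log units; beyond the scatter) in this assay, with 2,4,6-trimethylphenyl present on both sides of the step. Among the compounds shown here, the earlier step at this position stayed within the scatter, so this is the first clear sign that the group on the aromatic carbon affects the dose needed. Carrying 2,4,6-trimethylphenyl on the amide-type nitrogen is also not enough to give a measured dose, since compound 4 ends at a limit and not a number, the same limit as compound 3: the limit of > 1 mg/kg in this assay, at which 2 of the 4 values shown sit.

On these data alone, the steps with limits at both ends cannot be read, so any effect of exchanging 2,4,6-trifluorophenyl for 2,4,6-trimethylphenyl remains unknown. Also open, as far as these compounds go, is how an amine or a carboxylic acid on the aromatic carbon would compare with thiophen-2-yl.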